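Removing both methyl groups from the sulfonyl aryl

A few compounds are considered here, and "the series" means these few. Any claim that something is new, unique, unknown or untested is made for them only; others in the source may bear on it.

In an assay on isolated protein for displacement of a labelled ligand from metabotropic glutamate receptor 5 (Homo sapiens), with a stated time of 60 min, tested at 1 uM (a lower number here means less inhibition, a higher number more inhibition at the concentration tested (going by the name of the read-out)), compound 1 `Cc1ccc(S(=O)(=O)c2cnc3ccc(Cl)cc3c2N2CCC(C)CC2)cc1C` gives 84%. This is the second highest of the three numbers to hand: compound 2 `Cc1cc(C)cc(S(=O)(=O)c2cnc3cc(F)ccc3c2N2CCC(C)CC2)c1` gives 80%, within the scatter of compound 1, and compound 3 `CC1CCN(c2c(S(=O)(=O)c3ccc(Cl)c(Cl)c3)cnc3cc(F)ccc23)CC1` gives 94%, also within the scatter of compound 1. Within the data shown here, the one step measured in this assay, a number 14 percentage points higher from compound 2 to compound 3 (beyond the scatter), is the only step so far that changes the aryl group on the sulfonyl sulfur, and it is modest.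

Compound 4 `CC1CCN(c2c(S(=O)(=O)c3ccccc3)cnc3ccc(Cl)cc23)CC1` differs from compound 1 in one place: phenyl in place of 3,4-dimethylphenyl on a sulfonyl sulfur. Among the measured compounds shown here, no measured step removes substituents from this aryl group; the step from compound 2 to compound 3 exchanges one substituted aryl for another and so bears only loosely on it. The expectation is therefore a small downward step or none beyond the scatter, a number 9 percentage points lower from compound 1 to compound 4 (within the scatter). Compound 4 is estimated at 75% in this assay, with a range from 55% to 90%.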

Compound 4, a percentage reported as inhibition, at one concentration (the size of the read-out at that concentration, not a potency): 59%
The estimate for compound 4 lay 16 percentage points above the measured number; low and high end bracket the measured number.
By their numbers in this assay, from the lowest: compound 4; then compounds 2, 1 and 3 (each within the scatter of the next, the first and the last beyond it).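

In this assay, phenyl in place of 3,4-dimethylphenyl on the sulfonyl sulfur gives a number 25 percentage points lower from compound 1 to compound 4 (beyond the scatter). Among these compounds, the only earlier step at this position, a number 14 percentage points higher from compound 2 to compound 3 (beyond the scatter), exchanged one substituted aryl for another, whereas this one shows that the number does not hold when the two methyl groups are removed and the rest of compound 1 stays unchanged. The compounds shown offer no measured basis for explaining this loss.

On these data alone, it remains open whether a phenyl carrying a single methyl group would keep the number of compound 1 or fall to that of compound 4, and whether a methoxy group or a lone chlorine on the ring would serve in the same way. Also open, as far as these compounds go, is whether the same removal would give a step of similar size on the core of compound 2.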